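Oxazolyl in Place of Methoxy: Cytotoxicity Expectation

The source may report more compounds than this note shows. Statements on the series, on what has been measured and on what is new or still open speak of the compounds shown alone.

The two measured compounds, in an ADME assay on PC-3 cells (Homo sapiens) for cytotoxicity, read by WST assay, tested at 100 uM; on this read-out lower numbers stand for less inhibition and higher numbers for more inhibition at the one concentration tested (going by the name of the read-out):

Compound 1, `CS(=O)(=O)Nc1cccc(C(=O)N2CCCC(C(=O)Nc3ccc(Cl)cc3)C2)c1`, gives 3%.
Compound 2, `COc1cccc(C(=O)N2CCCC(C(=O)Nc3ccc(Cl)cc3)C2)c1`, gives 0%.

Compound 2 has the lowest of the two numbers; its nearest neighbour is compound 1, whose number is higher by an amount that lies within the scatter, so the two cannot be told apart. Compound 3, `O=C(Nc1ccc(Cl)cc1)C1CCCN(C(=O)c2cccc(-c3cnco3)c2)C1`, is not yet measured. It differs from compound 2 in one place: 1,3-oxazol-5-yl in place of methoxy on an aromatic carbon.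

For the measured compounds named here, only one measured step bears on this change, and it concerns the same aromatic carbon: a number 3 percentage points lower from compound 1 to compound 2 (within the scatter). That swap of one group for another at this position left the read-out essentially unchanged, and both measured compounds sit close to zero. Going by the values given here, there is no measured pair that shows how a five-membered aromatic ring at this place behaves, so the expectation rests on the near-absence of any effect so far. The estimated step is a number 3 percentage points higher from compound 2 to compound 3 (within the scatter), no change beyond the scatter. For compound 3 the expected value is 3%, with a range from -7% to 15%.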

Compound 3, a percentage reported as inhibition, at one concentration (the size of the read-out at that concentration, not a potency): 0%
Beside the measured number, compound 3's estimate is 3 percentage points above it; the range from low to high includes it.
By their numbers in this assay, from the lowest: compounds 2, 3 and 1 (each within the scatter of the next).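

In this assay, putting a five-membered aromatic ring on this aromatic carbon gives no change at the digits printed from compound 2 to compound 3 (within the scatter) and a number 3 percentage points lower from compound 1 to compound 3 (within the scatter). Until now, the position had been probed only with methoxy and methanesulfonamido, neither of which carries a ring; 1,3-oxazol-5-yl adds a ring with 2 hetero atoms and brings 5 heavy atoms where methoxy has 2, yet the three compounds still cannot be told apart in this read-out. The position has therefore taken three quite different groups without any difference beyond the scatter, though this holds only for these three compounds at the one concentration tested, and no accompanying measurement offers an explanation for the result.

The compounds shown leave open whether a group of another kind on this carbon, such as an amine, a carboxylic acid or a longer chain, would give a number that stands clear of the scatter. They also leave open whether a change elsewhere would do so, as the rest of the structure is the same in all three compounds.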